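Moving the Fluorine on the Ring-Nitrogen Aryl Group

The compounds below may be only part of what the source reports. "The series", "measured", "known", "first", "only" and "open" are said of these compounds alone.

Measured so far: compound 1 `COc1ccccc1N1C(=O)C(C)SC1c1cccc(C(=O)NCCCCc2ccccc2)c1` gives 38% in a functional assay on U2OS cells (Homo sapiens) for inhibition, read by CCK-8 assay, with a stated time of 72 h, tested at 1 uM; on this read-out lower numbers stand for less inhibition and higher numbers for more inhibition at the one concentration tested (going by the name of the read-out); compound 2 `O=C(NCCCCc1ccccc1)c1cccc(C2SCC(=O)N2c2cccc(F)c2)c1` gives 39%; compound 3 `CCOc1ccccc1N1C(=O)C(C)SC1c1cccc(C(=O)NCCCCc2ccccc2)c1` gives 37%.

Compound 2 carries the largest of the three numbers, yet its distance to compound 1 and to compound 3 lies within the usual scatter, so the three are not told apart. Compound 4 `O=C(NCCCCc1ccccc1)c1cccc(C2SCC(=O)N2c2ccccc2F)c1` differs from compound 2 as follows: 2-fluorophenyl in place of 3-fluorophenyl on an amide-type nitrogen in a ring. Within the data shown here, the only step measured so far, a number 1 percentage points lower from compound 1 to compound 3 (within the scatter), concerns a different part of the shared core and stayed within the scatter; no measured pair moves a fluorine on this aryl group. For compound 4 the expectation is therefore a step of no change at the digits printed from compound 2 to compound 4 (within the scatter), no change beyond the scatter. Compound 4 is estimated at 39%, between 25% and 52%.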

Compound 4, a percentage reported as inhibition, at one concentration (the size of the read-out at that concentration, not a potency): 38%
Beside the measured number, compound 4's estimate is 1 percentage points above it, within the range that was stated.
By their numbers in this assay, from the lowest: compounds 3, 1, 4 and 2 (each within the scatter of the next).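

In this assay, among these compounds, the change to 2-fluorophenyl from 3-fluorophenyl on the amide-type nitrogen in a ring gives a number 1 percentage points lower from compound 2 to compound 4 (within the scatter) and is the first measured step at this position. At the one concentration tested, these two placements of the fluorine cannot be told apart. Nothing measured here bears on why the two compounds read alike. From the compounds shown here alone, whether an amine or a carboxylic acid on this phenyl ring would shift the number stays open. Going by these compounds, how compound 2 and compound 4 compare at other concentrations also stays open.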